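Replacing isobutyl with cyclohexyl: an estimate for compound 4

A few compounds are considered here, and "the series" means these few. Any claim that something is new, unique, unknown or untested is made for them only; others in the source may bear on it.

Compound 1, `C#CCO/C=C/C(=O)OC`, gives in a functional assay on SW1573 cells (Homo sapiens) for antiproliferative activity, read by sulforhodamine B assay, with a stated time of 48 h (a lower number here means a stronger inhibitor of growth, a higher number a weaker inhibitor of growth), only a limit, > 100000 nM. Compound 2, `COC(=O)C#CC(CC(C)C)O/C=C/C(=O)OC`, gives 380 nM. Compound 3, `COC(=O)C#CC(C[C@@H](C)CCC=C(C)C)O/C=C/C(=O)OC`, gives 2200 nM.

Among the two plain numbers in this assay, compound 2 holds the lowest, so it is the stronger growth inhibitor of the pair; its nearest neighbour is compound 3, and the step of a 5.8-fold higher number from compound 2 to compound 3 (0.76 log units; beyond the scatter) is beyond the scatter. The value for compound 1 is a limit of the assay, not a number (the limit of > 100000 nM in this assay, at which 1 of the 3 values shown sits), so it cannot be compared in size.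

Compound 4, `COC(=O)C#CC(O/C=C/C(=O)OC)C1CCCCC1`, differs from compound 2 by cyclohexyl in place of isobutyl on a saturated chain carbon bound to an oxygen on an unsaturated carbon and a triple-bonded carbon. Among the measured compounds shown here, the only measured step that bears on it is the one from compound 2 to compound 3, where a larger hydrocarbon group in place of hydrogen raised the number modestly. The cyclohexyl of compound 4 adds carbon as well, though less than compound 3 gained, and keeps the group compact within a ring. A small rise, or none beyond the scatter, is therefore expected in this assay, with the step of a 1.7-fold higher number from compound 2 to compound 4 (0.23 log units; within the scatter) as the estimate. Compound 4 is expected to give about 650 nM, within 200 nM to 2200 nM.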

Compound 4, concentration for 50% growth inhibition: 2100 nM
The estimate for compound 4 lay 3.2-fold (0.51 log units) below the measured number; the measured number falls inside the stated range.
By their numbers in this assay, from the lowest: compound 2; then compounds 4 and 3 (each within the scatter of the next). At a limit, above all of these: compound 1.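

On this saturated chain carbon, bound to an oxygen on an unsaturated carbon and a triple-bonded carbon, a ring also raises the number in this assay: a 5.5-fold higher number from compound 2 to compound 4 (0.74 log units; beyond the scatter). Among the compounds shown here, until now the only step at this place was a 5.8-fold higher number from compound 2 to compound 3 (0.76 log units; beyond the scatter), which gave one example of a longer, open chain, so compound 4 adds a second and quite different group, and isobutyl still gives the lowest number among the compounds with plain values. Compound 3 at 2200 nM and compound 4 at 2100 nM lie within the scatter of each other, although one carries an open chain and the other a six-membered ring of carbon only, and nothing measured here explains why either group gives a higher number than isobutyl.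

From the compounds shown here alone, with only isobutyl, cyclohexyl and the longer chain of compound 3 to compare, it remains open whether a smaller ring such as cyclopropyl, a flat ring such as phenyl or a shorter chain such as ethyl would match or improve on compound 2. Going by these compounds, a chain ending in an amine or a carboxylic acid at this place is equally open, so the limits of what this position accepts are still unknown.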